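Pyrimidin-4-yl Amide in Place of Methoxypyridinyl Amide

A few compounds are considered here, and "the series" means these few. Any claim that something is new, unique, unknown or untested is made for them only; others in the source may bear on it.

Three compounds have been measured in a functional assay on NCI-H1975 cells (Homo sapiens) for antiproliferative activity, read by MTT assay, with a stated time of 72 h; on this read-out higher numbers stand for weaker inhibition and lower numbers for stronger inhibition:

Compound 1 `COc1cc(N(C)CCN(C)C)c(NC(=O)c2ccncn2)cc1Nc1nccc(-c2cn(C)c3ccccc23)n1`: 1560 nM
Compound 2 `COc1cc(N(C)C)c(NC(=O)c2ccnc(Cl)c2)cc1Nc1nccc(-c2cn(C)c3ccccc23)n1`: 9200 nM
Compound 3 `COc1ccc(C(=O)Nc2cc(Nc3nccc(-c4cn(C)c5ccccc45)n3)c(OC)cc2N(C)C)nc1`: 2130 nM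

Compound 3 holds the second highest of these three numbers; compound 1 lies within the scatter of it, compound 2 beyond it. Compound 4 `COc1cc(N(C)C)c(NC(=O)c2ccncn2)cc1Nc1nccc(-c2cn(C)c3ccccc23)n1` differs from compound 3 in one place: pyrimidin-4-yl in place of 5-methoxypyridin-2-yl on a carbonyl carbon. Among the compounds with values here, no measured step exchanges exactly these two groups. Within the data shown here, the only step at the carbonyl carbon, a 4.3-fold lower number from compound 2 to compound 3 (0.64 log units; beyond the scatter), shows that the heteroaryl on the amide can move the number modestly. The same pyrimidin-4-yl carbonyl as in compound 4, with a different amine, is carried by compound 1, which gives 1560 nM, within the scatter of compound 3. Compound 4 is therefore expected to show a 1.2-fold lower number from compound 3 to compound 4 (0.07 log units; within the scatter), a step within the scatter. Compound 4 is estimated at 1800 nM, ranging from 700 nM to 4500 nM.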

Compound 4, half-maximal inhibitory concentration: 1250 nM
Compound 4: middle estimate off by 1.4-fold (0.16 log units), on the high side; the measured number falls inside the stated range.
By their numbers in this assay, from the lowest: compounds 4, 1 and 3 (each within the scatter of the next); then compound 2.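

In this assay, the exchange on the carbonyl carbon gives a 1.7-fold lower number from compound 3 to compound 4 (0.23 log units; within the scatter), so this position does not separate pyrimidin-4-yl from 5-methoxypyridin-2-yl, while 2-chloropyridin-4-yl stands apart, with a 7.4-fold lower number from compound 2 to compound 4 (0.87 log units; beyond the scatter). With pyrimidin-4-yl in place, hydrogen for (dimethylamino)methyl on the saturated chain carbon gives a 1.2-fold lower number from compound 1 to compound 4 (0.10 log units; within the scatter), so this change to the amine also stays within the scatter. Nothing at hand gives a reason for these numbers. On these data alone, whether an amine or a carboxylic acid on the pyrimidin-4-yl ring would move the number remains open.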